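The source may report more compounds than this note shows. Statements on the series, on what has been measured and on what is new or still open speak of the compounds shown alone.

Working notes on the series. Compound 1 `CS(=O)(=O)Nc1ccccc1-c1ccc(COC2CC[C@H](N3CCCCCC3)[C@H]2OC/C=C\CCC(=O)O)cc1` is one of two compounds with a number in a functional assay for antagonist activity at thromboxane A2 receptor (Rattus norvegicus); on this read-out higher numbers stand for weaker binding and lower numbers for tighter binding; it gives 3.98 nM and stands at the lowest number of the two. Within the data shown here, compound 2 `O=C(O)CC/C=C\CO[C@H]1C(OCc2ccc(-c3ccc(CO)cc3)cc2)CC[C@@H]1N1CCCCCC1` gives 20 nM in this assay, and the step of a 5.0-fold higher number from compound 1 to compound 2 (0.70 log units; beyond the scatter) is the only change measured so far, a swap of one aromatic substituent for another. Compound 3 `CS(=O)(=O)Nc1ccccc1-c1ccc(CO[C@H]2CC[C@H](N3CCCCCC3)[C@H]2OC/C=C\CCC(=O)O)cc1` is the unmeasured one. Its difference from compound 1 is the two compounds have the same atoms and bonds; at least one stereo element is drawn with a configuration in one of them and without one in the other: 1 of 4 stereo elements differ; a stereocentre at a saturated ring carbon is drawn without a configuration in compound 1 and S in compound 3. Among the measured compounds shown here, no measured step involves a stereocentre drawn with or without a configuration, so the measured data do not bear directly on this change; compound 1 may already contain the form drawn as compound 3. The expectation for compound 3 is therefore a step of a 1.3-fold lower number from compound 1 to compound 3 (0.12 log units; within the scatter), not clearly beyond the scatter. Compound 3 is estimated at 3 nM, with a range from 1 nM to 12 nM.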

Compound 3, dissociation constant: 63.1 nM
For compound 3 the middle estimate is 21-fold (1.32 log units) below the measured one; the measured number lies above the stated range.
By their numbers in this assay, from the lowest: compound 1; then compound 2; then compound 3.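

Fixing this saturated ring carbon as S, with atoms and bonds unchanged, gives a 16-fold higher number from compound 1 to compound 3 (1.20 log units; beyond the scatter) in this assay. The earlier compounds shown here showed only a change at an aromatic substituent; this result shows that the drawn configuration at this ring carbon alone can carry a large step, and that the S form does not reproduce the number of compound 1. The step compares a defined form with an undefined one, so it does not tell what compound 1 contains at this carbon, and its reading is limited by one fact: the fact that one of compounds 1 and 3 is drawn with a defined configuration and the other without, at the place where they differ

Open, on these data alone, is whether the R form at this ring carbon gives a number lower than that of compound 3. Also open, as far as these compounds go, is how a 2-acetamidophenyl group in place of 2-(methanesulfonamido)phenyl would read with the S configuration in place.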